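Ethoxy to isopropoxy on a diaryl ether amine scaffold

The source may hold more compounds than are shown below. What is called first, only, known or untested is meant among the compounds shown, and "the series" means these compounds.

The measured compounds and their numbers:
compound 1, `COc1cccc(OC)c1OCCNCCOc1ccccc1OCc1cccc(C)c1`, 87100 nM;
compound 2, `CCOc1ccc(COc2ccccc2OCCNCCOc2c(OC)cccc2OC)cc1`, 51300 nM.

Both were read in a functional assay on PC-3 cells (Homo sapiens) for cytotoxicity, read by sulforhodamine B assay; on this read-out lower numbers stand for higher toxicity in this test and higher numbers for lower toxicity in this test. Compound 2 gives the lowest of the two numbers; its nearest neighbour is compound 1, and the step of a 1.7-fold lower number from compound 1 to compound 2 (0.23 log units; within the scatter) sits within the scatter, so the two cannot be ordered on this read-out.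

Compound 3, `COc1cccc(OC)c1OCCNCCOc1ccccc1OCc1ccc(OC(C)C)cc1`, has not yet been measured in this assay. It differs from compound 2 by methyl in place of hydrogen on a saturated chain carbon bound to an oxygen on an aromatic ring and a saturated chain carbon. Among the measured compounds shown here, no measured step touches this exact change; the only step available, a 1.7-fold lower number from compound 1 to compound 2 (0.23 log units; within the scatter), replaced one aryl group with another at the same part of the molecule and stayed within the scatter. That is a weak guide, and it suggests a small-to-no shift.

The expectation for compound 3 is therefore a number close to that of compound 2, with the step of a 1.1-fold lower number from compound 2 to compound 3 (0.06 log units; within the scatter) estimated to stay within the scatter. Compound 3 is estimated at 45000 nM, within a range from 20000 nM to 100000 nM.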

Compound 3, concentration lethal to 50% of the cells: 63100 nM
For compound 3 the middle estimate is 1.4-fold (0.15 log units) below the measured one; low and high end bracket the measured number.
By their numbers in this assay, from the lowest: compounds 2, 3 and 1 (each within the scatter of the next).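

In this assay, the step from ethoxy to isopropoxy, with methyl in place of hydrogen on a saturated chain carbon bound to an oxygen on an aromatic ring and a saturated chain carbon, gives a 1.2-fold higher number from compound 2 to compound 3 (0.09 log units; within the scatter) and so does not resolve any effect of this extra methyl on the read-out. The comparison with the 3-methylphenyl compound gives a 1.4-fold lower number from compound 1 to compound 3 (0.14 log units; within the scatter) for the 4-isopropoxyphenyl group, just as a 1.7-fold lower number from compound 1 to compound 2 (0.23 log units; within the scatter) does for the 4-ethoxyphenyl group, so neither of these two groups can be told apart from 3-methylphenyl in this test. No measured information is available that would account for these numbers.

On these data alone, whether a more drastic replacement at this position, such as a carboxylic acid, an amine or a longer chain in place of the isopropoxy group, would carry the number beyond the scatter remains open. Also open, as far as these compounds go, is how far the read-out depends on the methoxy groups and the secondary amine of the shared core, which stay the same in all three compounds.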